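Swapping the ring oxygen back for carbon

A few compounds are considered here, and "the series" means these few. Any claim that something is new, unique, unknown or untested is made for them only; others in the source may bear on it.

Compound 1 `COc1ncccc1C(=O)NCCC1CCN(S(=O)(=O)NC(=O)NC[C@H]2C[C@@H]3C=C[C@@H]2C3)CC1`: 20%
Compound 2 `COc1ncccc1C(=O)NCCC1CCN(S(=O)(=O)NC(=O)NC[C@H]2C[C@@H]3CC[C@@H]2O3)CC1`: 14%

In a functional assay on the whole organism (blood) with Rattus norvegicus as the target, with stated times of 24 h and 1 h, at a dose of 5 mg/kg by the intraperitoneal route (a higher number here means a stronger effect of the compound at the dose given, a lower number a weaker effect), compound 1 gives 20% and compound 2 gives 14%. For the measured compounds named here, compound 2 stands lowest of the two numbers, but its only neighbour is close: the step of a number 6 percentage points lower from compound 1 to compound 2 (within the scatter) lies within the scatter, so the two compounds cannot be told apart on these data. Compound 3 `COc1ncccc1C(=O)NCCC1CCN(S(=O)(=O)NC(=O)NC[C@@H]2C[C@@H]3CC[C@@H]2C3)CC1` has not yet been measured. It differs from compound 2 in one place: a group of 7 heavy atoms (7 carbon; 2 five-membered non-aromatic rings of carbon only) in place of a group of 7 heavy atoms (6 carbon, 1 oxygen; 2 five-membered non-aromatic rings with 1 hetero atom each), on a saturated chain carbon bound to an amide-type nitrogen. Going by the values given here, only one measured step bears on this change, a number 6 percentage points lower from compound 1 to compound 2 (within the scatter), which exchanged the same two kinds of group in the opposite direction and stayed within the scatter; the carbon-only group entering compound 3 is not exactly the one in compound 1, though. The step of a number 4 percentage points higher from compound 2 to compound 3 (within the scatter) is therefore expected to be small, in no direction beyond the scatter. Compound 3 is expected to give 18%, between 7% and 30%.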

Compound 3, a percentage reported as activity, at one dose (the size of the read-out at that dose, not a potency): 35%
Estimate against measurement, compound 3: 17 percentage points below; measured number above the stated range.
By their numbers in this assay, from the lowest: compounds 2 and 1 (each within the scatter of the next); then compound 3.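

In this assay, the group on the saturated chain carbon bound to an amide-type nitrogen now clearly affects the read-out, with a number 21 percentage points higher from compound 2 to compound 3 (beyond the scatter). Having only carbon in the group is not enough to explain this, as two all-carbon groups of 7 heavy atoms also differ, with a number 15 percentage points higher from compound 1 to compound 3 (beyond the scatter). Compound 3 therefore stands highest of the three, and the exact form of the carbon group matters here, not just the absence of the ring oxygen, although nothing available explains why.

Going by these compounds, it remains open how a single cyclopentane ring, or a group carrying an amine or a carboxylic acid, would behave at this place. These readings show only a stronger or weaker effect at the one dose given, and they leave open how the compounds would compare at any other dose.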